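A few compounds are considered here, and "the series" means these few. Any claim that something is new, unique, unknown or untested is made for them only; others in the source may bear on it.

The compounds measured in a functional assay on HeLa cells (Homo sapiens) for cytotoxicity, read by MTT assay, with a stated time of 48 h; a higher number here means a weaker inhibitor, a lower number a stronger inhibitor:
compound 1, `CCOC(=O)c1c(-c2c(Cl)c3ccccc3oc2=O)nn(-c2ccccc2)c1C(=O)OCC`, 100000 nM
compound 2, `CCOC(=O)c1c(-c2c(Cl)c3cc(C)ccc3oc2=O)nn(-c2cccc(C)c2)c1C(=O)OCC`, 115000 nM
compound 3, `CCOC(=O)c1c(-c2cc3ccccc3oc2=O)nn(-c2ccccc2)c1C(=O)OCC`, 100000 nM

In this assay compound 3 stands level with compound 1 at the digits shown, and the two together hold the lowest of the three numbers; compound 2 lies a little higher, but that gap is within the scatter. Compound 4, `CCOC(=O)c1c(-c2cc3ccccc3oc2=O)nn(-c2cccc(F)c2)c1C(=O)OCC`, has not been measured. It differs from compound 3 by fluoro in place of hydrogen on an aromatic carbon, the phenyl becoming 3-fluorophenyl. Going by the values given here, only one single-point step is available among the measured compounds: no change at the digits printed from compound 1 to compound 3 (within the scatter), which removed a halogen from the other aromatic ring and left the number unchanged. Compound 1 and compound 2, which differ at two places, also show values within the scatter of each other, so nothing measured here moves the number. On that basis compound 4 is expected to show no step beyond the scatter, no change at the digits printed from compound 3 to compound 4 (within the scatter). Compound 4 is therefore estimated at 100000 nM, with a range from 50000 nM to 200000 nM.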

Compound 4, half-maximal inhibitory concentration: 68000 nM
The estimate for compound 4 lay 1.5-fold (0.17 log units) above the measured number, within the range that was stated.
By their numbers in this assay, from the lowest: compounds 4, 1, 3 and 2 (each within the scatter of the next).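

In this assay the change from phenyl to 3-fluorophenyl gives a 1.5-fold lower number from compound 3 to compound 4 (0.17 log units; within the scatter) and is the only change shown that touches this ring alone. The earlier single-place step, no change at the digits printed from compound 1 to compound 3 (within the scatter), concerned a chloro on the other aromatic ring, so it said nothing about this ring taken by itself. At this place, on an aromatic carbon meta to a large group, fluoro in place of hydrogen does not move the number beyond the scatter.

As far as these compounds go, whether an amine, a carboxylic acid or a methoxy group at the same place would move it beyond the scatter remains open. So does whether fluoro at another carbon of this ring would behave the same way. No other measurement is at hand to account for these numbers.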